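The source may report more compounds than this note shows. Statements on the series, on what has been measured and on what is new or still open speak of the compounds shown alone.

In an ADME assay on microsomes from liver (Rattus norvegicus) for metabolic stability, read by LC-MS, tested at 1 mM (on this read-out lower numbers stand for a shorter-lived compound and higher numbers for a longer-lived compound), compound 2 `N#Cc1ccc(F)cc1Cn1c(N2CCC[C@@H](N)C2)nc2c(-c3ccc(S(N)(=O)=O)cc3)c[nH]c2c1=O` gives > 3.33 h, which is a limit of the assay and not a number. It therefore stands at the limit of > 3.33 h in this assay, at which 1 of the 3 values shown sits. Compound 1 `N#Cc1ccc(F)cc1Cn1c(N2CCC[C@@H](N)C2)nc2c(F)c[nH]c2c1=O` carries fluoro in the same place and gives 0.838 h. Compound 3 `N#Cc1ccc(F)cc1Cn1c(N2CCC[C@@H](N)C2)nc2c(-c3ccsc3)c[nH]c2c1=O` carries thiophen-3-yl there and gives 0.783 h. Going by the values given here, three measured steps bear on this place: an at least 3.9-fold higher number from compound 1 to compound 2 (0.59 log units; beyond the scatter), then an at least 4.2-fold lower number from compound 2 to compound 3 (0.62 log units; beyond the scatter), and a 1.1-fold lower number from compound 1 to compound 3 (0.03 log units; within the scatter). So the sulfamoylphenyl group of compound 2 is the only one here that moves the number beyond the scatter.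

Compound 4 `CS(=O)(=O)c1ccccc1-c1c[nH]c2c(=O)n(Cc3cc(F)ccc3C#N)c(N3CCC[C@@H](N)C3)nc12` changes that group again: 2-(methylsulfonyl)phenyl in place of 4-sulfamoylphenyl on an aromatic carbon. The new group also has one six-membered aromatic ring of carbon only and 2 double bonds outside aromatic rings, so it is compared with compound 2 and the step of an at least 3.9-fold higher number from compound 1 to compound 2 (0.59 log units; beyond the scatter) is expected to be largely kept. The step is only an estimate, and a small downward one within the scatter is expected: an at least 1.3-fold lower number from compound 2 to compound 4 (0.12 log units; that floor lies within the scatter). Compound 4 is expected to give 2.5 h, with an estimated range of 0.9 h to 6 h.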

Compound 4, half-life: 3.29 h
For compound 4 the middle estimate is 1.3-fold (0.12 log units) below the measured one, and the stated range covers the measured number.
By their numbers in this assay, from the lowest: compounds 3 and 1 (each within the scatter of the next); then compound 4. At a limit, above all of these: compound 2.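

In this assay, the 2-(methylsulfonyl)phenyl group also moves the number beyond the scatter, both against fluoro, a 3.9-fold higher number from compound 1 to compound 4 (0.59 log units; beyond the scatter), and against thiophen-3-yl, a 4.2-fold higher number from compound 3 to compound 4 (0.62 log units; beyond the scatter). So among the groups shown at this place, the longer half-life is not confined to the 4-sulfamoylphenyl group of compound 2, and it also appears with a group that has 0 hydrogen-bond donors. Compound 2 holds only a limit of the assay, so an at least 1.0-fold lower number from compound 2 to compound 4 (0.00 log units; that floor lies within the scatter) gives no more than a floor and sets no order between the two.

As far as these compounds go, the two groups differ both in their sulfur-bearing substituent and in where it sits on the phenyl ring, so it remains open which of these matters. Also open, from the compounds shown here alone, is whether a plain phenyl ring, or one carrying an amine or a carboxylic acid, would give a similar half-life.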